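Methoxy to fluoro on the benzyl group

The source may report more compounds than this note shows. Statements on the series, on what has been measured and on what is new or still open speak of the compounds shown alone.

Compound 1 `CCNCCNC(=O)c1cc(Cl)c(N)cc1OC`: > 30 mg/kg
Compound 2 `COc1cc(N)c(Cl)cc1C(=O)NCCN(C)CC1CCCCC1`: 3 mg/kg
Compound 3 `CCN(CCNC(=O)c1cc(Cl)c(N)cc1OC)Cc1ccc(OC)cc1`: 0.2 mg/kg

For the measured compounds named here, in a functional assay on the whole organism with Rattus norvegicus as the target (on this read-out lower numbers stand for an effect already at smaller amounts and higher numbers for an effect only at larger amounts of compound), compound 3 gives 0.2 mg/kg, the lowest number so far. Compound 2 gives 3 mg/kg. The gap between these two compounds lies beyond the scatter, with compound 2 on the higher side. For compound 1, > 30 mg/kg is a limit, not a number. Compound 4 `CCN(CCNC(=O)c1cc(Cl)c(N)cc1OC)Cc1ccc(F)cc1` carries fluoro in place of methoxy on an aromatic carbon, para to a large group (fluoro in place of methoxy on an aromatic carbon).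

Going by the values given here, the one measured step bearing on this is an at least 150-fold lower number from compound 1 to compound 3 (2.17 log units; beyond the scatter), with 4-methoxybenzyl in place of hydrogen on an amine nitrogen. Its size rests on (the limit of > 30 mg/kg in this assay, at which 1 of the 3 values shown sits). Among the compounds with values here, that step adds the whole group, whereas compound 4 keeps a 4-fluorobenzyl there, and no measured step exchanges methoxy for fluoro. Only a small change is therefore expected in this assay, with a slightly higher number if any.

The expected step is a 1.5-fold higher number from compound 3 to compound 4 (0.18 log units; within the scatter), which is not expected to pass the scatter. For compound 4 the estimated value is 0.3 mg/kg, with an expected range of 0.08 mg/kg to 1.2 mg/kg.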

Compound 4, dose for half-maximal effect: 0.2 mg/kg
Beside the measured number, compound 4's estimate is 1.5-fold (0.18 log units) above it; low and high end bracket the measured number.
By their numbers in this assay, from the lowest: compounds 3 and 4 (each within the scatter of the next); then compound 2. At a limit, above all of these: compound 1.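

In this assay, fluoro in place of methoxy on the benzyl group gives no change at the digits printed from compound 3 to compound 4 (within the scatter), so the methoxy group is not needed on this aromatic carbon for the low number. The 4-fluorobenzyl group also gives an at least 150-fold lower number from compound 1 to compound 4 (2.17 log units; beyond the scatter), so the large step seen earlier is not tied to 4-methoxybenzyl alone. Compound 1 stands at a limit, on which the size of that step rests: the limit of > 30 mg/kg in this assay, at which 1 of the 4 values shown sits.

The compounds shown leave open how a plain benzyl group, or a trifluoromethyl group on that aromatic carbon, would read in this assay. They also leave open the effect of a longer chain between the amine nitrogen and the phenyl ring.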